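The compounds below may be only part of what the source reports. "The series", "measured", "known", "first", "only" and "open" are said of these compounds alone.

Measured in a physicochemical assay for acid dissociation:
compound 1 `CC(=O)NCc1cccc(Cn2nc(NS(=O)(=O)c3ccc(Cl)s3)c3c(Cl)cccc32)c1` — 6.03
compound 2 `CC(=O)NCc1cccc(Cn2nc(NS(=O)(=O)c3ccc(Cl)s3)c3c(O)cccc32)c1` — 6.12

Compound 1 gives the lower of the two numbers in this assay, and compound 2 lies next to it by a number 0.09 log units higher from compound 1 to compound 2 (within the scatter), so the two values cannot be told apart.

Compound 3 `CC(=O)NCc1cccc(Cn2nc(NS(=O)(=O)c3ccc(Cl)s3)c3c(C(C)O)cccc32)c1` is not yet measured. It differs from compound 1 as follows: 1-hydroxyethyl in place of chloro on an aromatic carbon. For the measured compounds named here, the one measured step that bears on this change is the one from compound 1 to compound 2, where the chloro on the same aromatic carbon also gave way to a group carrying an oxygen, and that step was a number 0.09 log units higher from compound 1 to compound 2 (within the scatter), within the scatter. On that basis no step beyond the scatter is expected here either; the estimated step is a number 0.09 log units higher from compound 1 to compound 3 (within the scatter). For compound 3 the estimate in this assay is 6.12, with a range from 5.75 to 6.5.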

Compound 3, acid dissociation constant: 5.62
Compound 3: the middle estimate sits 0.50 log units above what was measured; the whole stated range lies above it.
By their numbers in this assay, from the lowest: compound 3; then compounds 1 and 2 (each within the scatter of the next).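

For the compounds shown here, with 1-hydroxyethyl on this aromatic carbon, this assay moves beyond the scatter for the first time, with a number 0.41 log units lower from compound 1 to compound 3 (beyond the scatter) and a number 0.50 log units lower from compound 2 to compound 3 (beyond the scatter) as the two steps, both towards a proton given up more readily. Compound 2 and compound 3 both carry oxygen at this carbon yet stand apart, so the presence of oxygen there does not by itself settle the reading, and this position is not indifferent to the group it holds. Nothing measured here accounts for this shift.

From the compounds shown here alone, whether the step follows the hydroxy of the side chain or its carbons remains open, and a plain ethyl or a hydroxymethyl group on the same carbon would separate the two. Going by these compounds, how far the reading moves with an amine or a carboxylic acid at this place also remains open.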